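The source may report more compounds than this note shows. Statements on the series, on what has been measured and on what is new or still open speak of the compounds shown alone.

Compound 1 `OCc1cc2ccccc2nc1-c1ccccc1O`: in a functional assay on IMR-32 cells (Homo sapiens) for cytotoxicity, read by MTT assay, with a stated time of 24 h (a lower number here means a stronger inhibitor, a higher number a weaker inhibitor), compound 1 gives > 100000 nM, a limit of the assay rather than a number.
Compound 2 `Cc1ccc2nc(-c3ccccc3O)c(CO)cc2c1`: compound 2 gives > 100000 nM, again a limit.
Compound 3 `OCc1cc2cc(F)c(F)cc2nc1-c1ccccc1O`: compound 3 gives 63000 nM.

Compound 2 thus stands at the limit of > 100000 nM in this assay, at which 2 of the 3 values shown sit. For the measured compounds named here, the only measured step, a step that the two limits leave unreadable from compound 1 to compound 2, runs between two limits and its size cannot be read. Compound 4 `OCc1cc2cc(Cl)ccc2nc1-c1ccccc1O` differs from compound 2 by chloro in place of methyl on an aromatic carbon. No measured step covers a chloro-for-methyl exchange, so nothing shown points to a clear direction; compound 3 with two fluoro groups carries a number, so a halogen at this core does not rule out a reading. The expected step of an at least 1.1-fold lower number from compound 2 to compound 4 (0.04 log units; that floor lies within the scatter) is therefore small. Compound 4 is estimated at 90000 nM, between 40000 nM and 200000 nM, with a fair chance of only a limit.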

Compound 4, half-maximal inhibitory concentration: 65000 nM
For compound 4 the middle estimate is 1.4-fold (0.14 log units) above the measured one; the measured number falls inside the stated range.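

For the compounds shown here, at this aromatic carbon, chloro gives the first readable number on this position: exchanging methyl for chloro gives an at least 1.5-fold lower number from compound 2 to compound 4 (0.18 log units; that floor lies within the scatter), and adding chloro in place of hydrogen gives an at least 1.5-fold lower number from compound 1 to compound 4 (0.18 log units; that floor lies within the scatter). Neither step shows a real gain, though the true size may be larger. Each is only a floor, set by a limit of the assay rather than a number: the limit of > 100000 nM in this assay, at which 2 of the 4 values shown sit.

The compounds shown leave open how large the chloro step truly is. They also leave open whether an amine or a carboxylic acid on this carbon would give a readable number in this assay.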